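A few compounds are considered here, and "the series" means these few. Any claim that something is new, unique, unknown or untested is made for them only; others in the source may bear on it.

Compound 1 `Oc1ccc(-c2cc(-c3ccccc3F)cc(-c3ccccc3O)n2)cc1` gives > 50000 nM in a functional assay on DU-145 cells (Homo sapiens) for inhibition (a higher number here means a weaker inhibitor, a lower number a stronger inhibitor), a limit of the assay. Compound 2 `Oc1ccc(-c2cc(-c3cccc(F)c3)cc(-c3ccccc3O)n2)cc1` gives > 50000 nM in this assay, again a limit. Compound 3 `Oc1ccc(-c2cc(-c3ccc(F)cc3)cc(-c3ccccc3O)n2)cc1` gives > 50000 nM in this assay, also a limit.

Compound 3 thus stands at the limit, as do the other two (the limit of > 50000 nM in this assay, at which 3 of the 3 values shown sit). The steps a step that the two limits leave unreadable from compound 1 to compound 2, a step that the two limits leave unreadable from compound 1 to compound 3 and a step that the two limits leave unreadable from compound 2 to compound 3 cannot be read, since both ends of each sit at the limit. Compound 4 `Oc1ccc(-c2cc(-c3ccc(F)cc3)cc(-c3ccc(O)cc3)n2)cc1` differs from compound 3 by 4-hydroxyphenyl in place of 2-hydroxyphenyl on an aromatic carbon. Going by the values given here, no measured step touches a hydroxyphenyl group, so none bears on this change. With all three measured values at the limit, compound 4 is estimated at 50000 nM, with a range from 10000 nM to 100000 nM. The step of a number no higher from compound 3 to compound 4 (the limit leaves the size open) is expected to be no more than the scatter allows to read.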

Compound 4, half-maximal inhibitory concentration: 6030 nM
The estimate for compound 4 lay 8.3-fold (0.92 log units) above the measured number; the whole stated range lies above it.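

The change to 4-hydroxyphenyl from 2-hydroxyphenyl, on the carbon next to the ring nitrogen, gives an at least 8.2-fold lower number from compound 3 to compound 4 (0.91 log units; beyond the scatter) in this assay. The steps among compound 1, compound 2 and compound 3 cannot be read, so this is the only change shown whose effect can be seen at all. Its full size stays open, since compound 3 sits at a limit of the assay: the limit of > 50000 nM in this assay, at which 3 of the 4 values shown sit.

As far as these compounds go, whether 4-hydroxyphenyl would have the same effect alongside 2-fluorophenyl or 3-fluorophenyl remains open. Also open, from the compounds shown here alone, is how an amine or a carboxylic acid would compare with the hydroxyl group on that ring.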